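The compounds below may be only part of what the source reports. "The series", "measured", "known", "first", "only" and "open" are said of these compounds alone.

Compound 2 `CCCn1c(=O)[nH]c2nc(-c3ccc(S(=O)(=O)N4CCN(c5ccc(C)cc5)CC4)cc3)[nH]c2c1=O` gives 25% in an assay on CHO cells for displacement of a labelled ligand from adenosine receptor A3 (Homo sapiens), read by scintillation counting, with a stated time of 45 min, tested at 1 uM, in the presence of a further agent that is not named here; a higher number here means more inhibition at the concentration tested (going by the name of the read-out), a lower number less inhibition. Within the data shown here, its only neighbour is compound 1 `CCCn1c(=O)[nH]c2nc(-c3ccc(S(=O)(=O)N4CCN(c5ccccc5Br)CC4)cc3)[nH]c2c1=O`, which gives 20% in this assay, and the step of a number 5 percentage points higher from compound 1 to compound 2 (within the scatter) means the two sit within the scatter of each other. Compound 3 `CCCn1c(=O)[nH]c2nc(-c3ccc(S(=O)(=O)N4CCN(c5ccc(I)cc5)CC4)cc3)[nH]c2c1=O` differs from compound 2 by iodo in place of methyl on an aromatic carbon. Among the measured compounds shown here, the one step in hand, from compound 1 to compound 2, exchanged the aryl group on the same amine nitrogen and moved the reading only within the scatter, so no step beyond the scatter is expected here: no change at the digits printed from compound 2 to compound 3 (within the scatter). Compound 3 is therefore estimated at 25%, in a range from 10% to 40%.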

Compound 3, a percentage reported as inhibition, at one concentration (the size of the read-out at that concentration, not a potency): 36%
The estimate for compound 3 lay 11 percentage points below the measured number; the measured number falls inside the stated range.
By their numbers in this assay, from the lowest: compounds 1 and 2 (each within the scatter of the next); then compound 3.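

In this assay iodo in place of methyl on this aromatic carbon gives a number 11 percentage points higher from compound 2 to compound 3 (beyond the scatter) and 4-iodophenyl in place of 2-bromophenyl gives a number 16 percentage points higher from compound 1 to compound 3 (beyond the scatter) so the reading can respond to the aryl group on the amine nitrogen, modestly, which the pair of compound 1 and compound 2 did not show. Nothing at hand accounts for this difference.
Open: whether the rise is specific to iodo or would also appear with bromo, chloro or fluoro at the same place, and how an amine, a carboxylic acid or a longer chain there would read.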